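Hydrazide extension of the pyridin-4-yl amide: lipophilicity outlook

The compounds below may be only part of what the source reports. "The series", "measured", "known", "first", "only" and "open" are said of these compounds alone.

Within a physicochemical assay for lipophilicity, read by HPLC, in phosphate buffer, measured as chromatographic lipophilicity, at pH 7.4 (a lower number here means a more polar compound, a higher number a more lipophilic compound), the series so far spans three amides on the shared core. Compound 1 `COc1ccc2nc(C)cc(OCC(=O)Nc3cccc(C)c3)c2c1` gives 4.83; compound 2 `COc1ccc2nc(C)cc(OCC(=O)Nc3cccnc3)c2c1` gives 2.46; compound 3 `COc1ccc2nc(C)cc(OCC(=O)Nc3ccncc3)c2c1` gives 2.5. The steps of a number 2.37 log units lower from compound 1 to compound 2 (beyond the scatter) and a number 2.33 log units lower from compound 1 to compound 3 (beyond the scatter) are both large, whereas a number 0.04 log units higher from compound 2 to compound 3 (within the scatter) sits within the scatter, so compound 3 stands with compound 2 well below compound 1. Compound 4 `COc1ccc2nc(C)cc(OCC(=O)NNC(=O)c3ccncc3)c2c1` carries ((pyridin-4-yl)carbonyl)amino in place of pyridin-4-yl on an amide-type nitrogen. Among the measured compounds shown here, no measured step covers this change; the measured steps only show that the two pyridyl amides sit close together. On that basis a moderate downward step a number 0.70 log units lower from compound 3 to compound 4 (beyond the scatter) is expected in this assay. Compound 4 is estimated at 1.8, with a range from 1 to 2.6.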

Compound 4, distribution coefficient: 1.48
The estimate for compound 4 lay 0.32 log units above the measured number; the measured number falls inside the stated range.
By their numbers in this assay, from the lowest: compound 4; then compounds 2 and 3 (each within the scatter of the next); then compound 1.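

In this assay, ((pyridin-4-yl)carbonyl)amino in place of pyridin-4-yl on an amide-type nitrogen gives a number 1.02 log units lower from compound 3 to compound 4 (beyond the scatter) even though the six-membered aromatic ring with 1 hetero atom is kept, so this position responds to more than the swap of one ring for another. The same group gives a number 0.98 log units lower from compound 2 to compound 4 (beyond the scatter) and a number 3.35 log units lower from compound 1 to compound 4 (beyond the scatter) and puts compound 4 lowest of the four. No measured evidence on hand bears on these steps.

Going by these compounds, whether a ((pyridin-3-yl)carbonyl)amino group would read like compound 4 remains open. So does the reading of a longer chain or a carboxylic acid on this nitrogen.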